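Replacing the sulfonamide substituent of compound 1

The source may hold more compounds than are shown below. What is called first, only, known or untested is meant among the compounds shown, and "the series" means these compounds.

Among the compounds with values here, in a functional assay on K562 cells (Homo sapiens) for antiproliferative activity, read by sulforhodamine B assay, with a stated time of 72 h (on this read-out higher numbers stand for weaker inhibition and lower numbers for stronger inhibition), compound 1 `Cc1cc(C)nc(NS(=O)(=O)c2ccc(Nc3nncc4ccccc34)cc2)n1` gives 4.9 nM and lies within the scatter of compound 2 `C(=C/c1ccccc1)\C(=N\Nc1nncc2ccccc12)c1ccccc1` at 4.4 nM at the low end of the numbers so far. Compound 3 `COc1ccc(NC(=S)NNc2nncc3ccccc23)cc1` reads clearly higher at 94 nM and so shows weaker inhibition than compound 1 does.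

Compound 4 `O=S(=O)(Nc1ccccn1)c1ccc(Nc2nncc3ccccc23)cc1` carries pyridin-2-yl in place of 4,6-dimethylpyrimidin-2-yl on a sulfonamide nitrogen and otherwise keeps the structure of compound 1. Within the data shown here, no measured pair isolates this change, so the data do not show directly what it does in this assay and the expectation starts from compound 1 at 4.9 nM alone. The expected 1.4-fold higher number from compound 1 to compound 4 (0.15 log units; within the scatter) is small, leaning towards a higher number, and probably stays inside the scatter. Compound 4 is estimated at 7 nM with an expected range from 2.5 nM to 30 nM on this read-out.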

Compound 4, half-maximal inhibitory concentration: 34 nM
Compound 4: middle estimate off by 4.9-fold (0.69 log units), on the low side; measured number above the stated range.
By their numbers in this assay, from the lowest: compounds 2 and 1 (each within the scatter of the next); then compound 4; then compound 3.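

In this assay, within the data shown here, the step of a 6.9-fold higher number from compound 1 to compound 4 (0.84 log units; beyond the scatter) is the first comparison that isolates a single place, and it shows that the group on the sulfonamide nitrogen affects the read-out. With pyridin-2-yl in place of 4,6-dimethylpyrimidin-2-yl, inhibition is weaker, so these two aromatic rings are not interchangeable at this position. The change alters both the methyl groups and the ring hetero atoms at once, and no available measurement accounts for the step.

From the compounds shown here alone, it remains open how much of the step belongs to the methyl groups and how much to the ring nitrogen; unsubstituted pyrimidin-2-yl and 4,6-dimethylpyridin-2-yl would separate the two. Going by these compounds, the effect of a non-aromatic group on the sulfonamide nitrogen, such as a short alkyl chain, also remains open.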